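A few compounds are considered here, and "the series" means these few. Any claim that something is new, unique, unknown or untested is made for them only; others in the source may bear on it.

In an in vitro ADME assay on microsomes from liver (Homo sapiens) for metabolic stability, tested at 1 uM (on this read-out higher numbers stand for a longer-lived compound and lower numbers for a shorter-lived compound), compound 3 (`CO[C@@H]1COCC[C@@H]1N[C@@H]1CC[C@@](C(=O)N2C[C@@H]3C[C@H]2CN3C(=O)C(C)(C)C)(C(C)C)C1`) stands at > 2 h, which is a limit and not a number. Compound 1 (`CC(C)[C@]1(C(=O)N2C[C@@H]3C[C@H]2CN3C(=O)C(C)(C)C)CC[C@@H](NC2CCOCC2)C1`) gives > 2 h, also a limit. Compound 2 (`CC(C)[C@]1(C(=O)N2C[C@@H]3C[C@H]2CN3C(=O)C2CCCC2)CC[C@@H](NC2CCOCC2)C1`) gives > 2 h, again a limit. The three compounds therefore share (the limit of > 2 h in this assay, at which 3 of the 3 values shown sit), and no order among them can be read.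

Compound 4 (`CO[C@@H]1COCC[C@@H]1N[C@@H]1CC[C@@](C(=O)N2C[C@@H]3C[C@H]2CN3C(=O)C2CCCC2)(C(C)C)C1`) differs from compound 3 by cyclopentyl in place of tert-butyl on a carbonyl carbon. The same exchange has been measured once without the methoxy group, as a step that the two limits leave unreadable from compound 1 to compound 2. The methoxy change itself appears as a step that the two limits leave unreadable from compound 1 to compound 3. Neither step has a readable size, so neither supplies a number to carry over. Within the data shown here, each shows only that a single change left the compound at the limit, and each rests on one pair.

No step beyond the scatter can be derived from these pairs, and no direction is expected. The estimated move is a step that the limit leaves unreadable from compound 3 to compound 4, and a report of the limit again is the likeliest outcome. For compound 4 the estimated half-life is 2.5 h, with an expected range of 1.3 h to 5 h.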

Compound 4, half-life: > 2 h
Compound 4: no number, only a limit; the forecaster's own chance of this, stated with the estimate: 80%; the middle value lies beyond the limit too.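

No step can be read from compound 3 to compound 4 or from compound 2 to compound 4 in this assay, since each pair ends in two limits: the limit of > 2 h in this assay, at which 4 of the 4 values shown sit.

The compounds shown leave open how long the half-lives of compound 1, compound 2, compound 3 and compound 4 actually are, and whether either exchange changes them.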